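The source may hold more compounds than are shown below. What is called first, only, known or untested is meant among the compounds shown, and "the series" means these compounds.

Measured in an ADME assay (liver) for metabolic stability, with Liver microsome (Homo sapiens) as the target, read by LC-MS, using microsomes, tested at 1 uM; a lower number here means that the compound disappears faster, a higher number that the compound lasts longer:

- Compound 1 `CC(C)/C(=N/c1ccnc2cc(Cl)ccc12)NCCCCN1CCCCC1`: 0.483 h
- Compound 2 `C/C(=N/c1ccnc2cc(Cl)ccc12)NCCCN1CCCCC1`: > 1 h

Compound 2 has no exact half-life on these numbers. In this assay compound 2 gives only a limit, > 1 h.

Compound 3 `CC(C)/C(=N/c1ccnc2cc(Cl)ccc12)NCCCN1CCCCC1` has not yet been measured. It differs from compound 2 by isopropyl in place of methyl on a carbon with a double bond to nitrogen, with isopropyl in place of methyl on a carbon with a double bond to nitrogen. Going by the values given here, no measured pair isolates this change, so the size of the step remains uncertain. A moderate shortening of the half-life is nevertheless expected, since compound 1 also carries isopropyl and gives 0.483 h. The expected change is an at least 1.6-fold lower number from compound 2 to compound 3 (0.22 log units; that floor lies within the scatter). For compound 3 the estimated half-life is 0.6 h, with an expected range of 0.3 h to 1.2 h.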

Compound 3, half-life: 0.483 h
The estimate for compound 3 lay 1.2-fold (0.09 log units) above the measured number; measured number inside the range.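

In this assay, isopropyl in place of methyl on a carbon with a double bond to nitrogen now has its first isolated reading, an at least 2.0-fold lower number from compound 2 to compound 3 (0.31 log units; beyond the scatter), so this position does respond to the change. That step is only a floor, and compound 2 gives a limit rather than a number: the limit of > 1 h in this assay, at which 1 of the 3 values shown sits. With isopropyl held constant, piperidin-1-yl in place of (piperidin-1-yl)methyl on a saturated chain carbon, three bonds along the chain from an amine nitrogen, gives no change at the digits printed from compound 1 to compound 3 (within the scatter), so this pair shows no effect of the chain length.

From the compounds shown here alone, the full size of the methyl-to-isopropyl step stays open, as does whether it would hold on the longer chain of compound 1. Going by these compounds, what a cyclopropyl group on that carbon or a morpholine in place of the piperidin-1-yl would do is also open.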